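The source may report more compounds than this note shows. Statements on the series, on what has been measured and on what is new or still open speak of the compounds shown alone.

Measured compounds:
Compound 1 `Cc1ccccc1-n1nncc1CN1C(=O)C2(C(C#N)=C(N)Oc3c2c2nc4ccccc4nc2c2ccccc32)c2ccccc21` gives, in a functional assay on HCT-116 cells (Homo sapiens) for antiproliferative activity, read by MTT assay, with a stated time of 48 h (a higher number here means a weaker inhibitor, a lower number a stronger inhibitor), > 50000 nM, which is a limit of the assay.
Compound 2 `N#CC1=C(N)Oc2c(c3nc4ccccc4nc3c3ccccc23)C12C(=O)N(Cc1cnnn1-c1ccc([N+](=O)[O-])cc1)c1ccccc12` gives in this assay > 50000 nM, again a limit.
Compound 3 `Cc1ccc(-n2nncc2CN2C(=O)C3(C(C#N)=C(N)Oc4c3c3nc5ccccc5nc3c3ccccc43)c3ccccc32)cc1C` gives in this assay > 50000 nM, also a limit.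

Compound 1 therefore stands nowhere on a numerical scale: only a limit is known for it, and the same holds for its two neighbours, since (the limit of > 50000 nM in this assay, at which 3 of the 3 values shown sit). The steps a step that the two limits leave unreadable from compound 1 to compound 2 and a step that the two limits leave unreadable from compound 1 to compound 3 cannot be read, nor can a step that the two limits leave unreadable from compound 2 to compound 3.

Compound 4 `Cc1cc(C)cc(-n2nncc2CN2C(=O)C3(C(C#N)=C(N)Oc4c3c3nc5ccccc5nc3c3ccccc43)c3ccccc32)c1` is the compound not yet measured. Its change from compound 1 is 3,5-dimethylphenyl in place of 2-methylphenyl on an aromatic nitrogen. For the measured compounds named here, of the measured steps, the one from compound 1 to compound 3, where a 3,4-dimethylphenyl enters on the same aromatic nitrogen, is the closest in kind, and that step was unreadable. Nothing in the data suggests that a 3,5-dimethylphenyl would behave differently from the groups already tried.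

The expected step is accordingly a number no higher from compound 1 to compound 4 (the limit leaves the size open), that is none that can be read against the limits. Compound 4 is estimated in this assay at 50000 nM, within 20000 nM to 200000 nM, most likely reported again only as a limit.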

Compound 4, half-maximal inhibitory concentration: > 50000 nM
Compound 4 ended at the assay's limit; the forecaster's own chance of this, stated with the estimate: 85%; the middle value lies on the limit itself.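

The steps from compound 1, compound 2 and compound 3 to compound 4 cannot be read, because all four compounds stand at one assay limit: the limit of > 50000 nM in this assay, at which 4 of the 4 values shown sit.

The compounds shown leave open how far apart these four lie in this assay, and whether any group on this aromatic nitrogen would give a measurable value.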